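The compounds below may be only part of what the source reports. "The series", "measured", "known", "first", "only" and "open" are said of these compounds alone.

In a functional assay on HCT-116 cells (Homo sapiens) for cytotoxicity (on this read-out lower numbers stand for stronger inhibition and higher numbers for weaker inhibition), compound 1 `COc1ccc(C2=C(c3ccccc3)C(=O)N3CCCC3C2)cc1` gives 390 nM. Among the compounds with values here, compound 2 `COc1ccc(C2=C(c3ccccn3)C(=O)N3CCCC3C2)cc1` gives 104000 nM in this assay, the highest of the two numbers so far; the only step measured, a 270-fold higher number from compound 1 to compound 2 (2.43 log units; beyond the scatter), is large. Compound 3 `COc1ccc(C2=C(c3ccncc3)C(=O)N3CCCC3C2)cc1` differs from compound 2 by pyridin-4-yl in place of pyridin-2-yl on a double-bonded ring carbon. Within the data shown here, no measured step exchanges one pyridyl isomer for another, so the direction of this change rests only on the position of compound 2 at the weak end and on the size of the step from compound 1. Some recovery is expected, a 6.9-fold lower number from compound 2 to compound 3 (0.84 log units; beyond the scatter), with wide uncertainty. Compound 3 is therefore estimated at 15000 nM, within 1500 nM to 100000 nM.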

Compound 3, half-maximal inhibitory concentration: 19000 nM
Compound 3: the middle estimate sits 1.3-fold (0.10 log units) below what was measured; measured number inside the range.
By their numbers in this assay, from the lowest: compound 1; then compound 3; then compound 2.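

In this assay, the exchange of pyridin-2-yl for pyridin-4-yl gives a 5.5-fold lower number from compound 2 to compound 3 (0.74 log units; beyond the scatter), so at this double-bonded ring carbon the place of the ring nitrogen matters, not only its presence. The pyridin-4-yl still does not reach the phenyl level, with a 49-fold higher number from compound 1 to compound 3 (1.69 log units; beyond the scatter), so both pyridyl isomers shown remain weaker than the phenyl of compound 1. Nothing available explains either step. On these data alone, the place of pyridin-3-yl in this order stays open. Also open, as far as these compounds go, is whether a phenyl carrying a fluorine or an amine at this carbon would hold the level of compound 1.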